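Benzamide aryl swap: methylsulfonyl out, chloro in

A few compounds are considered here, and "the series" means these few. Any claim that something is new, unique, unknown or untested is made for them only; others in the source may bear on it.

Compound 1 `O=C(Nc1ccc(Cl)c(-c2nnc3c(Cl)cccn23)c1)c1cccc(Cl)c1` gives 43100 nM in a functional assay on U-251 cells (Homo sapiens) for antiproliferative activity, read by MTT assay, with a stated time of 72 h; a lower number here means a stronger inhibitor, a higher number a weaker inhibitor. Compound 2 `O=C(Nc1ccc(Cl)c(-c2nnc3c(Cl)cccn23)c1)c1ccccc1` gives 73500 nM in this assay. Compound 3 `CS(=O)(=O)c1cccc(C(=O)Nc2ccc(Cl)c(-c3nnc4c(Cl)cccn34)c2)c1` returns only a limit of this assay, > 100000 nM, and so stands at the weak end of the values shown; the limit of > 100000 nM in this assay, at which 1 of the 3 values shown sits, marks that ceiling. Of the measured steps, an at least 2.3-fold higher number from compound 1 to compound 3 (0.36 log units; beyond the scatter), while an at least 1.3-fold higher number from compound 2 to compound 3 (0.13 log units; that floor lies within the scatter). Compound 4 `O=C(Nc1ccc(Cl)c(-c2nnc3c(Cl)cccn23)c1)c1ccccc1Cl` is not yet measured and differs from compound 3 by 2-chlorophenyl in place of 3-(methylsulfonyl)phenyl on a carbonyl carbon. This removes the methylsulfonyl whose entry weakened compound 3 relative to compound 1, although compound 4 carries its chloro within a 2-chlorophenyl rather than in the arrangement found in compound 1, so the two are not the same substitution. For compound 4 the expected step is an at least 1.6-fold lower number from compound 3 to compound 4 (0.22 log units; that floor lies within the scatter). Compound 4 is estimated at 60000 nM, with a range from 25000 nM to 150000 nM. That would return compound 4 to the neighbourhood of the values shown by compound 1 and compound 2, with a real chance that this assay again reports only a limit.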

Compound 4, half-maximal inhibitory concentration: > 100000 nM
Compound 4 was reported as a limit; the forecaster's own chance of this, stated with the estimate: 30%; middle value at least 1.6-fold (0.22 log units) from the limit.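

Replacing 3-chlorophenyl with 2-chlorophenyl on the carbonyl carbon gives an at least 2.3-fold higher number from compound 1 to compound 4 (0.36 log units; beyond the scatter), so in this assay the same chloro does not carry the same result at both places on that phenyl. Adding chloro to the unsubstituted phenyl gives an at least 1.3-fold higher number from compound 2 to compound 4 (0.13 log units; that floor lies within the scatter), a floor that does not establish a real change from compound 2. Removing the methylsulfonyl does not by itself bring the series off the assay ceiling, and the step between compound 3 and compound 4 cannot be read, as both are limits: the limit of > 100000 nM in this assay, at which 2 of the 4 values shown sit.

As far as these compounds go, how far compound 3 and compound 4 lie beyond that limit remains unknown. Also open, from the compounds shown here alone, is whether an amine or a carboxylic acid in place of the chloro of the 3-chlorophenyl would give a readable value.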